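This account rests on a few compounds, and the source may have more. Where it says the series, first, only, none or still open, it means among the compounds named here.

Measured compounds:

Compound 1 `COc1ccc(CC2CCCCN2C(=O)n2ncc(C(O)(c3ccc(F)cc3)c3ccc(F)cc3)n2)cc1`: 5.01 nM
Compound 2 `COC(c1ccc(F)cc1)(c1ccc(F)cc1)c1cnn(C(=O)N2CCCCC2Cc2ccccc2)n1`: 12.6 nM
Compound 3 `O=C(N1CCCCC1COc1ccc(F)cc1)n1ncc(C(O)(c2ccc(F)cc2)c2ccc(F)cc2)n1`: 5.01 nM

In an assay on HEK-293T cells for inhibition of diacylglycerol lipase-alpha (Homo sapiens), read by colorimetric assay (a lower number here means a stronger inhibitor, a higher number a weaker inhibitor), compound 3 stands level with compound 1 at the digits given, and the two together carry the lowest numbers of the three; compound 2 gives the highest. For the measured compounds named here, the single one-point step so far is no change at the digits printed from compound 1 to compound 3 (within the scatter), so swapping the group on the saturated chain carbon bound to the saturated ring carbon left the read-out where it was.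

Compound 4 `COc1cccc(CC2CCCCN2C(=O)n2ncc(C(O)(c3ccc(F)cc3)c3ccc(F)cc3)n2)c1` differs from compound 3 by 3-methoxyphenyl in place of 4-fluorophenoxy on a saturated chain carbon bound to a saturated ring carbon. Going by the values given here, this returns to a methoxyphenyl group at the same place as in compound 1, though not the same methoxyphenyl; no measured step speaks to the methoxy group's change of position. Among the compounds with values here, the only relevant comparison is the step from compound 1 to compound 3, which was flat, so a small move at most is expected for compound 4 in this assay, with no direction favoured beyond the scatter, and the step of a 1.3-fold higher number from compound 3 to compound 4 (0.10 log units; within the scatter) is estimated to stay inside it. Compound 4 is therefore expected at about 6.3 nM, within 2.5 nM to 16 nM.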

Compound 4, half-maximal inhibitory concentration: 3.16 nM
Compound 4: middle estimate off by 2.0-fold (0.30 log units), on the high side; the measured number falls inside the stated range.
By their numbers in this assay, from the lowest: compounds 4, 1 and 3 (each within the scatter of the next); then compound 2.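

In this assay, the place on a saturated chain carbon bound to a saturated ring carbon now carries a third group with no change beyond the scatter: a 1.6-fold lower number from compound 3 to compound 4 (0.20 log units; within the scatter). For the compounds shown here, the step of a 1.6-fold lower number from compound 1 to compound 4 (0.20 log units; within the scatter) is the first reading on where the methoxy group sits on the aromatic ring, and it shows that 3-methoxyphenyl and 4-methoxyphenyl cannot be told apart in this assay. Nothing measured explains why these groups read alike.

As far as these compounds go, the three compounds compared here all keep an aromatic ring at this place, so it remains open whether an amine or a carboxylic acid on that ring, or a longer chain at this place, would hold the read-out. Also open, from the compounds shown here alone, is whether any group here can move the number beyond the scatter.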